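Methoxy Additions on the Aryl Ring of a Dienone Series

This account rests on a few compounds, and the source may have more. Where it says the series, first, only, none or still open, it means among the compounds named here.

Of the compounds shown here, three of one series have been measured in a functional assay on A549 cells (Homo sapiens) for antiproliferative activity, read by MTT assay, with a stated time of 72 h; a lower number here means a stronger inhibitor, a higher number a weaker inhibitor. Compound 1 `COc1ccccc1/C=C/C(=O)/C=C/c1nc(C)c(C)nc1C` gives 3200 nM in this assay. Compound 2 `COc1ccc(/C=C/C(=O)/C=C/c2nc(C)c(C)nc2C)cc1OC` gives 3790 nM in this assay. Compound 3 `COc1ccc(/C=C/C(=O)/C=C/c2nc(C)c(C)nc2C)c(OC)c1` gives 3070 nM in this assay. The three numbers lie within the scatter of one another, so no order among them can be read from the data. The difference between the core of compound 1 and the core of compound 2 is not broken down here.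

Compound 1 and compound 3 differ in one place: methoxy in place of hydrogen on an aromatic carbon This change gave a 1.0-fold lower number from compound 1 to compound 3 (0.02 log units; within the scatter).

Compound 4 `COc1cc(/C=C/C(=O)/C=C/c2nc(C)c(C)nc2C)cc(OC)c1OC` has not yet been measured in this assay. It differs from compound 2 in one place: methoxy in place of hydrogen on an aromatic carbon The surroundings of the place are not the same as in compound 3: there the entering methoxy sat meta to a methoxy group and para to a large group, here it sits ortho to a methoxy group, meta to a large group and meta to a methoxy group. It is therefore the same kind of change, not the same change.

The expected step is a 1.1-fold lower number from compound 2 to compound 4 (0.03 log units; within the scatter), which rests on the earlier step of a 1.0-fold lower number from compound 1 to compound 3 (0.02 log units; within the scatter) and on compound 2 giving 3790 nM in a set whose values all lie within the scatter. Compound 4 is expected to give about 3500 nM in this assay, estimated between 1700 nM and 7500 nM.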

Compound 4, half-maximal inhibitory concentration: 1600 nM
For compound 4 the middle estimate is 2.2-fold (0.34 log units) above the measured one; measured number below the stated range.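

In this assay, methoxy in place of hydrogen on an aromatic carbon gave a 2.4-fold lower number from compound 2 to compound 4 (0.37 log units; beyond the scatter), a modest step, and the entering methoxy sits ortho to a methoxy group, meta to a large group and meta to a methoxy group. Set beside the earlier step on the other core, the new step does not stand apart from it, so the two cores give no firm sign that the size of this change depends on the core: the same change on two cores in this assay, a 1.0-fold lower number (0.02 log units; within the scatter) from compound 1 to compound 3 and a 2.4-fold lower number (0.37 log units; beyond the scatter) from compound 2 to compound 4, 2.3-fold (0.36 log units) apart, within the scatter of two such steps. Among these compounds, this does not show that the change carries over with a fixed size, since only two steps are at hand, one within the scatter and one beyond it, and the surroundings of the entering methoxy are not the same in the two; the data neither establish transfer between cores nor rule out a real difference between them.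

Every aryl substituent shown is a methoxy group, which leaves open whether a hydroxyl group, a fluorine or chlorine atom, or an amine on the same ring would give a step of similar size in this assay. Also open, from the compounds shown here alone, is whether a longer chain such as ethoxy in place of methoxy would follow the same course as compound 4.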